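The source may hold more compounds than are shown below. What is called first, only, known or untested is meant among the compounds shown, and "the series" means these compounds.

Measured so far:
- compound 1 `COc1ccccc1N1CCN(CCCCCCOc2ccc(C(=O)Nc3ccccc3OCCCC(=O)O)cc2)CC1`: 9500 nM
- compound 2 `COc1ccccc1N1CCN(CCC(Oc2ccc(NC(=O)c3ccccc3OCCCC(=O)O)cc2)c2ccccc2)CC1`: 730 nM
- compound 3 `COc1ccccc1N1CCN(CCC(Oc2ccc(NC(=O)c3ccccc3OCCCC(=O)O)cc2)c2ccc(C)cc2)CC1`: 440 nM

In an assay on isolated protein for inhibition of steroid 5-alpha-reductase (Rattus norvegicus) (a lower number here means a stronger inhibitor, a higher number a weaker inhibitor), compound 3 gives the lowest of the three numbers, but the step of a 1.7-fold lower number from compound 2 to compound 3 (0.22 log units; within the scatter) lies within the scatter, so compound 2 and compound 3 cannot be told apart on these data. Going by the values given here, compound 1 stands furthest off: compound 1 gives 9500 nM where compound 3 gives 440 nM, a gap beyond the scatter, though no single-point step connects these two.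

Compound 4 `CCc1ccc(C(CCN2CCN(c3ccccc3OC)CC2)Oc2ccc(NC(=O)c3ccccc3OCCCC(=O)O)cc2)cc1` differs from compound 3 by methyl in place of hydrogen on a saturated chain carbon bound to an aromatic carbon. Among the compounds with values here, the only measured step of comparable size is a 1.7-fold lower number from compound 2 to compound 3 (0.22 log units; within the scatter), a methyl added on an aromatic carbon, which stayed within the scatter. Within the data shown here, no measured step touches the saturated chain carbon in question, so the expectation rests on that one step alone. The step of a 1.0-fold lower number from compound 3 to compound 4 (0.02 log units; within the scatter) is therefore expected to remain within the scatter, with no clear direction. For compound 4 in this assay the estimate is 420 nM, with a range from 180 nM to 1000 nM.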

Compound 4, half-maximal inhibitory concentration: 130 nM
Estimate against measurement, compound 4: 3.2-fold (0.51 log units) above, outside the stated range (below it).
By their numbers in this assay, from the lowest: compound 4; then compounds 3 and 2 (each within the scatter of the next); then compound 1.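

In this assay, methyl in place of hydrogen on a saturated chain carbon bound to an aromatic carbon, which turns 4-methylphenyl into 4-ethylphenyl, gives a 3.4-fold lower number from compound 3 to compound 4 (0.53 log units; beyond the scatter), a change beyond the scatter, unlike the earlier 1.7-fold lower number from compound 2 to compound 3 (0.22 log units; within the scatter). Ethyl in place of hydrogen on the aromatic carbon gives a 5.6-fold lower number from compound 2 to compound 4 (0.75 log units; beyond the scatter), so this position does respond to substitution, and on these compounds ethyl is separated from hydrogen where methyl is not. Nothing available bears on the reason for this gain.

Three compounds at one position leave open whether the number keeps falling with a longer chain such as propyl or butyl, or with a branched group such as isopropyl. From the compounds shown here alone, it is also open whether the gain depends on a carbon chain at all, as a methoxy group or a chlorine atom at this position would show.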